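The compounds below may be only part of what the source reports. "The series", "measured", "known", "first", "only" and "open" are said of these compounds alone.

Three compounds sharing one core differ in the amide part. Compound 1 `CCCc1cc(N)c2cc(NC(=O)/C=C/c3ccc(Cl)cc3)ccc2n1` gives 6 nM in an assay on isolated protein for displacement of a labelled ligand from melanin-concentrating hormone receptor 1 (Homo sapiens) (on this read-out lower numbers stand for stronger inhibition and higher numbers for weaker inhibition), the highest of the three numbers. Compound 2 `CCCc1cc(N)c2cc(NC(=O)c3ccc(-c4ccc(Cl)cc4)cc3)ccc2n1` gives 0.7 nM in this assay, a number lower than that of compound 1 by more than the usual scatter, and compound 3 `CC(C)(C)c1cc(N)c2cc(NC(=O)/C=C/c3ccc(C(F)(F)F)cc3)ccc2n1` gives 0.3 nM, lower still and also beyond the scatter from compound 1. Compound 4 `CCCc1cc(N)c2cc(NC(=O)/C=C/c3ccccc3)ccc2n1` remains unmeasured. It differs from compound 1 in one place: hydrogen in place of chloro on an aromatic carbon, a change that cut one bond further out reads 4-chlorophenyl to phenyl. The step is expected to read a 5.0-fold higher number from compound 1 to compound 4 (0.70 log units; beyond the scatter), toward weaker inhibition. For compound 4 the estimate is 30 nM, within a range of 8 nM to 120 nM.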

Compound 4, half-maximal inhibitory concentration: 1000 nM
The estimate for compound 4 lay 33-fold (1.52 log units) below the measured number; measured number above the stated range.
By their numbers in this assay, from the lowest: compound 3; then compound 2; then compound 1; then compound 4.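

In this assay, replacing chloro with hydrogen on the aromatic carbon gives a 170-fold higher number from compound 1 to compound 4 (2.22 log units; beyond the scatter), toward weaker inhibition. The earlier compounds shown here carried a group at this place in every case, and this step shows that, on the core of compound 1, a single chlorine atom there makes a large difference to the number. Nothing available accounts for the size of this step. On these data alone, whether a fluoro, methyl or methoxy group on that carbon would give a number nearer that of compound 1 remains open.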